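This account rests on a few compounds, and the source may have more. Where it says the series, first, only, none or still open, it means among the compounds named here.

Series notes, step from compound 3 to compound 4.

Going by the values given here, compound 3 `CC/C(=C(/c1ccc(/C=C/C(=O)O)cc1)c1cc2ccccc2[nH]1)c1ccc(Cl)cc1` gives 343 nM in a functional assay on MCF7 cells (Homo sapiens) for inhibition (on this read-out higher numbers stand for weaker inhibition and lower numbers for stronger inhibition), the highest of the three numbers measured so far. Its nearest neighbour is compound 2 `CC/C(=C(/c1ccc(/C=C/C(=O)O)cc1)c1cc2ccccc2[nH]1)c1ccccc1OC(F)(F)F`, which gives 206 nM; the step of a 1.7-fold higher number from compound 2 to compound 3 (0.22 log units; within the scatter) is within the scatter. Furthest is compound 1 `CC/C(=C(/c1ccc(/C=C/C(=O)O)cc1)c1cc2ccccc2[nH]1)c1ccccc1C#N`, which gives 9 nM; the step of a 38-fold higher number from compound 1 to compound 3 (1.58 log units; beyond the scatter) is large.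

Compound 4 `CC/C(=C(/c1ccc(/C=C/C(=O)O)cc1)c1cc2ccccc2[nH]1)c1ccc(C#N)cc1` differs from compound 3 by cyano in place of chloro on an aromatic carbon, on an aromatic carbon of a six-membered ring of carbon only, para to a large group.

Among the compounds with values here, no measured step exchanges cyano for chloro at this place. Within the data shown here, two steps bear indirectly: a 23-fold higher number from compound 1 to compound 2 (1.36 log units; beyond the scatter) replaced cyano with trifluoromethoxy and cost much, and a 38-fold higher number from compound 1 to compound 3 (1.58 log units; beyond the scatter) swapped 2-cyanophenyl for 4-chlorophenyl and cost more. Both moves away from a cyano group on this aryl gave weaker inhibition, but in compound 1 the cyano sits in a different position on the ring, so the gain cannot be assumed to transfer fully.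

On balance, a moderate move toward stronger inhibition is expected for compound 4, a 4.3-fold lower number from compound 3 to compound 4 (0.63 log units; beyond the scatter). Compound 1 gives 9 nM, and compound 4 is not expected to reach a number as low as that. Compound 4 is estimated at 80 nM, range 15 nM to 400 nM.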

Compound 4, half-maximal inhibitory concentration: 278 nM
Compound 4: the middle estimate sits 3.5-fold (0.54 log units) below what was measured, within the range that was stated.
By their numbers in this assay, from the lowest: compound 1; then compounds 2, 4 and 3 (each within the scatter of the next).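

In this assay, cyano and chloro on an aromatic carbon para to a large group are not told apart (a 1.2-fold lower number from compound 3 to compound 4 (0.09 log units; within the scatter)). The 4-cyanophenyl group of compound 4 also stands level with the 2-(trifluoromethoxy)phenyl group of compound 2 (a 1.3-fold higher number from compound 2 to compound 4 (0.13 log units; within the scatter)), so compounds 2, 3 and 4 now form a single cluster within the scatter of each other. Having a nitrile on this phenyl ring is therefore not enough for the low number: the two nitrile isomers lie far apart (a 31-fold higher number from compound 1 to compound 4 (1.49 log units; beyond the scatter)), and among the compounds shown only the 2-cyanophenyl group of compound 1 separates from the rest.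

No available data explain why the place of the nitrile on this ring matters so much. Going by these compounds, it also remains open whether chloro in the place the nitrile holds in compound 1 would keep the low number, and whether an amine, a methoxy group or a fluoro group there would do the same.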